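The source may report more compounds than this note shows. Statements on the series, on what has been measured and on what is new or still open speak of the compounds shown alone.

Three compounds share one core and differ only in the chain on the aromatic carbon of the five-membered ring: compound 1 `CCCCCCCCCCc1ccc(-c2noc(CCCCN)n2)cc1`, compound 2 `CCCCCCCCCCc1ccc(-c2noc(CCCNC)n2)cc1` and compound 3 `CCCCCCCCCCc1ccc(-c2noc(CC(O)CN)n2)cc1`. In an assay on HeLa cells for inhibition of sphingosine-1-phosphate transporter SPNS2 (Mus musculus), read by LC-MS, tested at 2 uM (a higher number here means more inhibition at the concentration tested (going by the name of the read-out), a lower number less inhibition), compound 1 gives 55%, compound 2 gives 45% and compound 3 gives 59%. Compound 3 holds the highest of the three numbers, within the scatter of compound 1 but separated from compound 2, as a number 14 percentage points higher from compound 2 to compound 3 (beyond the scatter) shows. The other steps, a number 10 percentage points lower from compound 1 to compound 2 (within the scatter) and a number 4 percentage points higher from compound 1 to compound 3 (within the scatter), stay within the scatter. Compound 4 `CCCCCCCCCCc1ccc(-c2noc([C@@H](N)CCN)n2)cc1` differs from compound 3 by 1,3-diaminopropyl in place of 3-amino-2-hydroxypropyl on an aromatic carbon. Going by the values given here, no measured step covers this exchange; all three steps on this chain were small, so little movement in this assay beyond the scatter is expected, in either direction. Compound 4 is therefore estimated at 50% with a range from 35% to 65%. That estimate corresponds to a number 9 percentage points lower from compound 3 to compound 4 (within the scatter).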

Compound 4, a percentage reported as inhibition, at one concentration (the size of the read-out at that concentration, not a potency): 14%
Beside the measured number, compound 4's estimate is 36 percentage points above it, and the stated range ends above it.
By their numbers in this assay, from the lowest: compound 4; then compounds 2, 1 and 3 (each within the scatter of the next, the first and the last beyond it).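

Going by these compounds alone, the chain on this aromatic carbon is more sensitive than the earlier compounds showed: in this assay, 1,3-diaminopropyl in place of 3-amino-2-hydroxypropyl gives a number 45 percentage points lower from compound 3 to compound 4 (beyond the scatter), far larger than any earlier step. The drop also holds against the other two chains, with a number 31 percentage points lower from compound 2 to compound 4 (beyond the scatter) and a number 41 percentage points lower from compound 1 to compound 4 (beyond the scatter), so compound 4 stands apart from all three. No evidence on the reason for this drop is available.

Going by these compounds, it remains open whether the drop follows the second amine of 1,3-diaminopropyl or its defined stereocentre. Also open, on these data alone, is how the opposite stereoisomer, or a carboxylic acid or guanidine at the chain end, would read here.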